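Dropping the ethyl branch from the chain of compound 1

A few compounds are considered here, and "the series" means these few. Any claim that something is new, unique, unknown or untested is made for them only; others in the source may bear on it.

The measured compounds in this series are:
compound 1, `CCCC(CCOc1ccc(-c2ccc(Cl)cc2)cc1)CCN1CCN(c2ccncc2)C1=O`, with > 25000 nM in an ADME assay on cells (Homo sapiens) for cytotoxicity; a higher number here means that more compound is tolerated, a lower number that less compound is tolerated;
compound 2, `CC(C)(CCCOc1ccc(-c2ccc(Cl)cc2)cc1)CN1CCN(c2ccncc2)C1=O`, with 20000 nM in this assay;
compound 3, `O=C1N(CCOCCOc2ccc(-c3ccc(Cl)cc3)cc2)CCN1c1ccncc1`, with 25000 nM in this assay.

Compound 1 stands at a limit in this assay: the assay reports for compound 1 only (the limit of > 25000 nM in this assay, at which 1 of the 3 values shown sits), not a number. Compound 2 and compound 3 give numbers that sit close to that limit, and nothing here separates any of the three by more than the usual scatter of this assay. Among the measured compounds shown here, no single-point step between measured compounds is recorded, so the only footing is that all three share a core that is tolerated up to the top of the range.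

Compound 4, `CC(CCOc1ccc(-c2ccc(Cl)cc2)cc1)CCN1CCN(c2ccncc2)C1=O`, has not yet been measured. It differs from compound 1 by hydrogen in place of ethyl on a saturated chain carbon, four bonds along the chain from an amide-type nitrogen in a ring and an oxygen on an aromatic ring. On the evidence at hand, the step from compound 1 to compound 4 is expected to be a number no higher from compound 1 to compound 4 (the limit leaves the size open), that is, none beyond the scatter, because compound 1 itself already rests at the limit of > 25000 nM in this assay, at which 1 of the 3 values shown sits. Compound 4 is therefore expected to give about 25000 nM in this assay, within a range from 12000 nM to 50000 nM, with a fair chance that the assay again returns only a limit.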

Compound 4, half-maximal cytotoxic concentration: > 25000 nM
Compound 4 was reported as a limit (the forecaster's own chance of this, stated with the estimate: 55%); the middle value sits exactly at the limit.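

In this assay compound 4 gives > 25000 nM, a limit of the assay and not a number. Compound 1 is likewise reported only as a limit, and no step can be read between compound 1 and compound 4. The compounds shown leave open whether replacing the ethyl branch with hydrogen changes the tolerated concentration at all.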